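Swapping the Ketone Aryl Group in a Cytotoxicity Series

The compounds below may be only part of what the source reports. "The series", "measured", "known", "first", "only" and "open" are said of these compounds alone.

Compound 3 `COc1cccc(C(=O)CC2C(C#N)=C(N)Oc3ccc(Br)cc32)c1` stands highest of the three compounds measured in an ADME assay on MCF-10A cells (Homo sapiens) for cytotoxicity, read by sulforhodamine B assay, with a stated time of 72 h, tested at 10 uM; on this read-out lower numbers stand for a weaker effect and higher numbers for a stronger effect at the one concentration tested: compound 3 gives 101%. Its nearest neighbour is compound 1 `COC(=O)C1=C(N)Oc2ccc(Br)cc2C1CC(=O)c1ccc(Br)cc1`, which gives 39.9%, and the furthest is compound 2 `COc1cccc(C(=O)CC2C(C#N)=C(N)Oc3c(OC)cc(Br)cc32)c1`, which gives 32.3%. Among the measured compounds shown here, the only single-point step among them, a number 68.7 percentage points higher from compound 2 to compound 3 (beyond the scatter), shows that one small change on the shared core can move this read-out a long way.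

Compound 4 `N#CC1=C(N)Oc2ccc(Br)cc2C1CC(=O)c1ccc(Br)cc1` differs from compound 3 in one place: 4-bromophenyl in place of 3-methoxyphenyl on a carbonyl carbon. For the measured compounds named here, no measured pair shows this swap on its own, so no step bears on it directly. Compound 1 carries the same 4-bromophenyl on its carbonyl carbon, though with a methyl ester in place of the nitrile on the core, and its value lies far below that of compound 3. Compound 4 is therefore expected to land between those two, an estimated step of a number 41 percentage points lower from compound 3 to compound 4 (beyond the scatter). For compound 4 the estimate is 60%, with a range from 25% to 100%.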

Compound 4, a percentage reported as activity, at one concentration (the size of the read-out at that concentration, not a potency): 32.6%
For compound 4 the middle estimate is 27.4 percentage points above the measured one; low and high end bracket the measured number.
By their numbers in this assay, from the lowest: compounds 2, 4 and 1 (each within the scatter of the next); then compound 3.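

The carbonyl carbon turns out to be a sensitive position: with the rest of the molecule unchanged, 4-bromophenyl in place of 3-methoxyphenyl gives a number 68.4 percentage points lower from compound 3 to compound 4 (beyond the scatter) in this assay. The change on the double-bonded ring carbon, cyano in place of methoxycarbonyl, gives a number 7.3 percentage points lower from compound 1 to compound 4 (within the scatter), so with 4-bromophenyl in place, the nitrile and the ester cannot be told apart on this read-out. Nothing available explains why the aryl swap produces a step of this size.

A plain phenyl on the carbonyl carbon would help show whether the step follows the loss of the methoxy group or the arrival of the bromine. Going by these compounds, it also remains open whether the nitrile and the ester would still match with 3-methoxyphenyl on the carbonyl carbon.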